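This account rests on a few compounds, and the source may have more. Where it says the series, first, only, none or still open, it means among the compounds named here.

Measured in an assay on isolated protein for inhibition of vitamin D3 receptor (Homo sapiens); on this read-out lower numbers stand for stronger inhibition and higher numbers for weaker inhibition:
compound 1 `N=c1scc(-c2ccccc2)n1CC(=O)N1CCOCC1` gives 24400 nM
compound 2 `CC(=O)N1CCN(C(=O)Cn2c(-c3ccc(C)cc3)csc2=N)CC1` gives 2840 nM
compound 3 `CC(=O)N1CCN(C(=O)Cn2c(-c3ccc(Cl)cc3)csc2=N)CC1` gives 2280 nM

Compound 3 holds the lowest of the three numbers; compound 2 sits within the scatter of it, while compound 1 lies beyond the scatter from it. For the measured compounds named here, the only single-place step known, a 1.2-fold lower number from compound 2 to compound 3 (0.10 log units; within the scatter), is within the scatter and concerns the aromatic carbon, not the ring amine. Compound 4 `N=c1scc(-c2ccc(Cl)cc2)n1CC(=O)N1CCN(c2ccccc2)CC1` differs from compound 3 by phenyl in place of acetyl on an amine nitrogen in a ring. Going by the values given here, no measured step touches this place; compound 1 and compound 3 differ in two places, so their gap cannot be assigned to the ring nitrogen substituent alone. The step of a 1.5-fold lower number from compound 3 to compound 4 (0.18 log units; within the scatter) in this assay is therefore expected to be small, with a wide range. Compound 4 is estimated at 1500 nM, between 350 nM and 6500 nM.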

Compound 4, inhibition constant: 3070 nM
Beside the measured number, compound 4's estimate is 2.0-fold (0.31 log units) below it; the measured number falls inside the stated range.
By their numbers in this assay, from the lowest: compounds 3, 2 and 4 (each within the scatter of the next); then compound 1.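

In this assay, phenyl in place of acetyl on the ring amine nitrogen gives a 1.3-fold higher number from compound 3 to compound 4 (0.13 log units; within the scatter), the first single-place step read at this position. The read-out does not separate the two groups, even though the exchange removes a hydrogen-bond acceptor and adds a six-membered aromatic ring. No available evidence accounts for this result.

From the compounds shown here alone, it remains open whether a carboxylic acid, a basic amine or a longer chain on this nitrogen would stay within the same range. Also open, going by these compounds, is whether phenyl and acetyl stay equivalent with methyl in place of chloro on the aromatic carbon.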